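A fluorine moved on the benzyl arm of compound 1

The compounds below may be only part of what the source reports. "The series", "measured", "known", "first", "only" and "open" are said of these compounds alone.

Compound 1 `COc1ccc2c(=O)c(/C=C/C(=O)NCc3cccc(F)c3)coc2c1` is measured in a functional assay on HeLa cells (Homo sapiens) for inhibition, read by MTT assay, with a stated time of 48 h (a higher number here means a weaker inhibitor, a lower number a stronger inhibitor), where compound 1 gives 17600 nM. Of the two numbers recorded in this assay, that is the higher one. Compound 2 `Cc1ccccc1NC(=O)/C=C/c1coc2cc(O)ccc2c1=O` gives 8670 nM in this assay, a step of an at least 11-fold higher number from compound 2 to compound 3 (1.06 log units; beyond the scatter) away from compound 3 `Cc1ccc(CNC(=O)/C=C/c2coc3cc(O)ccc3c2=O)cc1`. Compound 3 itself shows only a limit of the assay, > 100000 nM, as described in the limit of > 100000 nM in this assay, at which 1 of the 3 values shown sits. Compound 4 `COc1ccc2c(=O)c(/C=C/C(=O)NCc3ccc(F)cc3)coc2c1` has not yet been measured.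

The change from compound 1 to compound 4 is 4-fluorophenyl in place of 3-fluorophenyl on a saturated chain carbon bound to an amide-type nitrogen. Going by the values given here, only one measured step exists in this set, the one from compound 2 to compound 3, and it concerns 4-methylbenzyl in place of 2-methylphenyl on an amide-type nitrogen; it does not move a fluorine on a benzyl group and so does not bear directly on the present step. Among the compounds with values here, with no matching step, the expectation rests on the closeness of the two structures: compound 4 is expected to give roughly the same number as compound 1, with a step of a 1.3-fold higher number from compound 1 to compound 4 (0.10 log units; within the scatter) that need not exceed the usual scatter. The estimate for compound 4 in this assay is 22000 nM, with a range from 7000 nM to 70000 nM.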

Compound 4, half-maximal inhibitory concentration: > 100000 nM
Compound 4 ended at the assay's limit; the forecaster's own chance of this, stated with the estimate: 15%; at least 4.5-fold (0.65 log units) between middle value and limit.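

The earlier compounds shown here held no step that changed only where one atom sits on the benzyl arm; here, 4-fluorophenyl in place of 3-fluorophenyl on a saturated chain carbon bound to an amide-type nitrogen gives an at least 5.6-fold higher number from compound 1 to compound 4 (0.75 log units; beyond the scatter) in this assay. Moving the fluorine alone, with the same atoms and the same core, is therefore enough to change the reading at this position, even though the two groups match in heavy atoms, ring, hydrogen-bond donors and hydrogen-bond acceptors. Because the result for compound 4 is a limit rather than a number, the step has a known minimum but no known full size: the limit of > 100000 nM in this assay, at which 2 of the 4 values shown sit.

From the compounds shown here alone, what a plain benzyl group without fluorine, a chlorobenzyl group or a longer phenylethyl chain would give on this amide nitrogen remains open. Also open, going by these compounds, is whether the same fluorine move would have a similar effect on a core carrying a hydroxyl group, as in compound 2 and compound 3, in place of the methoxy group of compound 1.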